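From compound 2 to compound 4: a longer carbonyl substituent

The source may hold more compounds than are shown below. What is called first, only, known or untested is meant among the compounds shown, and "the series" means these compounds.

compound 1 `C=CCCCCCCCCCOC[C@@H]1CCCN1C(=O)OC(C)(C)C`: >= 100000 nM (a limit)
compound 2 `CCCCCCCC/C=C\CCCCCCCCOC[C@@H]1CCCN1C(=O)OC(C)(C)C`: 80000 nM
compound 3 `CCCCCCCC/C=C/CCCCCCCCOC[C@@H]1CCCN1C(=O)OC(C)(C)C`: > 100000 nM (a limit)

In a functional assay on PANC-1 cells (Homo sapiens) for inhibition, read by XTT assay, with a stated time of 72 h (on this read-out higher numbers stand for weaker inhibition and lower numbers for stronger inhibition), compound 2 gives 80000 nM. Going by the values given here, the values of compound 1 and compound 3 are limits of the assay, so compound 2 holds the only actual number of the three. Compound 4 `CCCCCCCC/C=C\CCCCCCCCOC[C@@H]1CCCN1C(=O)[C@@H]1CCCN1C(=O)OC(C)(C)C` keeps the chain of compound 2 and changes at the other end: 1-(tert-butoxycarbonyl)pyrrolidin-2-yl takes the place of tert-butoxy on a carbonyl carbon (1-(tert-butoxycarbonyl)pyrrolidin-2-yl in place of tert-butoxy on a carbonyl carbon).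

The measured steps bear on this only indirectly, as all of them change the chain and none changes the carbonyl substituent. The data show an at least 1.2-fold lower number from compound 1 to compound 2 (0.09 log units; that floor lies within the scatter) and an at least 1.2-fold higher number from compound 2 to compound 3 (0.09 log units; that floor lies within the scatter), both with floors inside the scatter, while a step that the two limits leave unreadable from compound 1 to compound 3. Compound 3 differs from compound 2 in a single respect: the fact that compounds 2 and 3 differ only in the configuration as drawn.

With compound 2 at 80000 nM as the only anchor, no step beyond the scatter is expected in this assay, in either direction. The expected change is a 1.1-fold lower number from compound 2 to compound 4 (0.06 log units; within the scatter). For compound 4 the estimated value is 70000 nM, with an expected range of 25000 nM to 160000 nM.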

Compound 4, half-maximal inhibitory concentration: > 100000 nM
Compound 4: only a limit was reported (the forecaster's own chance of this, stated with the estimate: 40%); middle value at least 1.4-fold (0.15 log units) from the limit.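

In this assay compound 4 gives > 100000 nM, which is a limit of the assay and not a number. This is the only change shown on this carbonyl carbon, and 1-(tert-butoxycarbonyl)pyrrolidin-2-yl in place of tert-butoxy gives an at least 1.2-fold higher number from compound 2 to compound 4 (0.09 log units; that floor lies within the scatter), so the new group brings no readable gain and the true size of the step stays hidden. Compound 2 remains the only one of the four compounds with an actual number, and the change at the carbonyl end reaches the same ceiling as the change in the chain of compound 3: the limit of > 100000 nM in this assay, at which 2 of the 4 values shown sit.

The compounds shown leave open whether any group on this carbonyl carbon can give a clearly lower number than compound 2 does. A pyrrolidin-2-yl with a free amine, or a simple primary amine in place of tert-butoxy, would test this.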